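The source may hold more compounds than are shown below. What is called first, only, known or untested is meant among the compounds shown, and "the series" means these compounds.

In a functional assay on MDA-MB-231 cells (Homo sapiens) for antiproliferative activity, read by MTT assay, with a stated time of 72 h (on this read-out higher numbers stand for weaker inhibition and lower numbers for stronger inhibition), compound 1 `CC1=CC[C@H]2[C@H](CC[C@]2(C)O)C(C)(C)[C@@H]1CC[C@H]1[C@]2(C)CC[C@H](OC(=O)c3ccncc3)C(C)(C)O[C@H]2CC[C@@]1(C)O` gives 18000 nM and compound 2 `CC1=CC[C@H]2[C@H](CC[C@]2(C)O)C(C)(C)[C@@H]1CC[C@H]1[C@]2(C)CC[C@H](OC(=O)NS(=O)(=O)c3ccc(C)cc3)C(C)(C)O[C@H]2CC[C@@]1(C)O` gives 47100 nM, the higher of the two numbers, so compound 2 is the weaker inhibitor so far. Compound 3 `CC1=CC[C@H]2[C@H](CC[C@]2(C)O)C(C)(C)[C@@H]1CC[C@H]1[C@]2(C)CC[C@H](OC(=O)c3ccc(C(F)(F)F)cc3)C(C)(C)O[C@H]2CC[C@@]1(C)O` differs from compound 2 in one place: 4-(trifluoromethyl)phenyl in place of ((4-methylphenyl)sulfonyl)amino on a carbonyl carbon. For the measured compounds named here, only one measured step bears on this swap: a 2.6-fold higher number from compound 1 to compound 2 (0.42 log units; beyond the scatter), which brought in the group that leaves here. Compound 3 has a ring directly on the carbonyl carbon, like compound 1 at 18000 nM, so a similarly modest move back is expected. In this assay the expected step is a 2.1-fold lower number from compound 2 to compound 3 (0.33 log units; beyond the scatter). The estimate for compound 3 is 22000 nM, within an expected range of 8000 nM to 55000 nM.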

Compound 3, half-maximal inhibitory concentration: 19500 nM
Compound 3: the middle estimate sits 1.1-fold (0.05 log units) above what was measured, within the range that was stated.
By their numbers in this assay, from the lowest: compounds 1 and 3 (each within the scatter of the next); then compound 2.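

In this assay, the swap on the carbonyl carbon from ((4-methylphenyl)sulfonyl)amino to 4-(trifluoromethyl)phenyl gives a 2.4-fold lower number from compound 2 to compound 3 (0.38 log units; beyond the scatter), so a second ring attached directly to that carbon, not only pyridin-4-yl, goes with the lower numbers. Exchanging pyridin-4-yl for 4-(trifluoromethyl)phenyl gives a 1.1-fold higher number from compound 1 to compound 3 (0.03 log units; within the scatter), so this assay does not separate these two rings. No measurement here explains either result. Going by these compounds, how a simple amine or a short alkyl chain on the carbonyl carbon would compare remains open.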